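Swapping methoxy for chloro on a low-inhibition aromatic core

The source may hold more compounds than are shown below. What is called first, only, known or untested is meant among the compounds shown, and "the series" means these compounds.

Measured compounds:
compound 1 `COc1ccc(N)c(C(=O)CCNC(=O)C2CC2)c1` — 2.66%
compound 2 `COc1ccc(N)c(C(=O)CCNC(=O)C2CCC2)c1` — 0.01%
compound 3 `COc1ccc(N)c(C(=O)CCNC(=O)C2CCCCC2)c1` — 9.24%

In an assay for inhibition of Nitric oxide synthase, inducible (Homo sapiens), read by scintillation counting, with a stated time of 30 min, tested at 1 mM (a higher number here means more inhibition at the concentration tested (going by the name of the read-out), a lower number less inhibition), compound 1 gives 2.66%. Among the measured compounds shown here, the three numbers lie close together: the step of a number 2.7 percentage points lower from compound 1 to compound 2 (within the scatter) and the step of a number 6.6 percentage points higher from compound 1 to compound 3 (within the scatter) are both within the scatter, as is a number 9.2 percentage points higher from compound 2 to compound 3 (within the scatter), so no measured compound can be set apart from the others, and all three sit at very low inhibition.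

Compound 4 `Nc1ccc(Cl)cc1C(=O)CCNC(=O)C1CC1` has not yet been measured. It differs from compound 1 in one place: chloro in place of methoxy on an aromatic carbon. For the measured compounds named here, no measured step touches this position; the three steps recorded all concern the ring on the carbonyl carbon, and each of them stayed within the scatter. Nothing in the data therefore points to a change beyond the scatter for a substitution on the aromatic ring, and the whole series gives the same weak picture.

The step of a number 0.3 percentage points higher from compound 1 to compound 4 (within the scatter) is accordingly expected to be small, in either direction, and within the scatter. Compound 4 is estimated at 3%, with a range from 0% to 12%.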

Compound 4, a percentage reported as inhibition, at one concentration (the size of the read-out at that concentration, not a potency): 5.37%
The estimate for compound 4 lay 2.4 percentage points below the measured number; the measured number falls inside the stated range.
By their numbers in this assay, from the lowest: compounds 2, 1, 4 and 3 (each within the scatter of the next).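

Chloro in place of methoxy on this aromatic carbon, para to the amino group and meta to a large group, is the first change in the series outside the ring on the carbonyl carbon, and in this assay it gives a number 2.7 percentage points higher from compound 1 to compound 4 (within the scatter). The aromatic position therefore behaves like the ring on the carbonyl carbon in this small set: exchanging methoxy, with two heavy atoms and one hydrogen-bond acceptor, for chloro, with one heavy atom and no hydrogen-bond acceptor, does not set compound 4 apart from compound 1, and the series stays without a separated compound. No measurement shown bears on the reason for this outcome, so the result stands as an observation only.

The compounds shown leave open whether a carboxylic acid or a dimethylamino group on the same aromatic carbon would produce a step beyond the scatter, where methoxy and chloro do not. They also leave open whether chloro would read the same way on the cores carrying cyclobutyl or cyclohexyl on the carbonyl carbon.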